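The source may hold more compounds than are shown below. What is called first, only, known or untested is meant among the compounds shown, and "the series" means these compounds.

Measured in a functional assay on MGC-803 cells (Homo sapiens) for inhibition, read by sulforhodamine B assay; on this read-out higher numbers stand for weaker inhibition and lower numbers for stronger inhibition:
compound 1, `O=C1C=C(NCc2ccccc2)C(=O)c2c1nc1n2[C@H]2OC[C@@H](O)[C@H]2OC1`: 2670 nM
compound 2, `O=C1C(NC2CC2)=CC(=O)c2c1nc1n2[C@H]2OC[C@@H](O)[C@H]2OC1`: a limit of the assay only, > 4000 nM
compound 3, `CCOc1ccc(NC2=CC(=O)c3c(nc4n3[C@H]3OC[C@@H](O)[C@H]3OC4)C2=O)cc1`: 2090 nM

Compound 1 stands highest of the two numbers, with compound 3 within the scatter of it; the remaining value, for compound 2, is a limit only (the limit of > 4000 nM in this assay, at which 1 of the 3 values shown sits). Compound 4, `O=C1C=C(Nc2ccc(I)cc2)C(=O)c2c1nc1n2[C@H]2OC[C@@H](O)[C@H]2OC1`, differs from compound 1 by 4-iodophenyl in place of benzyl on an amine nitrogen. Among the compounds with values here, the one measured step that bears on this change, 4-ethoxyphenyl in place of cyclopropyl on the amine nitrogen, is an at least 1.9-fold lower number from compound 2 to compound 3 (0.28 log units; that floor lies within the scatter), and its floor lies within the scatter. Compound 3, which carries 4-ethoxyphenyl on that nitrogen, sits within the scatter of compound 1, so for compound 4 no step beyond the scatter is expected in this assay, a 1.2-fold lower number from compound 1 to compound 4 (0.08 log units; within the scatter). The estimate for compound 4 in this assay is 2200 nM, with a range from 900 nM to 4500 nM.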

Compound 4, half-maximal inhibitory concentration: 1400 nM
Estimate against measurement, compound 4: 1.6-fold (0.20 log units) above, and the stated range covers the measured number.
By their numbers in this assay, from the lowest: compounds 4, 3 and 1 (each within the scatter of the next). At a limit, above all of these: compound 2.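

In this assay, 4-iodophenyl in place of benzyl on this amine nitrogen gives a 1.9-fold lower number from compound 1 to compound 4 (0.28 log units; within the scatter). A phenyl ring bound directly to the nitrogen therefore reads no differently from benzyl in this assay. Compound 3 and compound 4, with 4-ethoxyphenyl and 4-iodophenyl, also stand within the scatter of each other, so the two groups cannot be told apart here.

Compound 2 remains a limit only: the limit of > 4000 nM in this assay, at which 1 of the 4 values shown sits.

Going by these compounds, whether a carboxylic acid or an amine on the phenyl ring, or a longer chain in place of benzyl, would move the number beyond the scatter stays open.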